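The source may hold more compounds than are shown below. What is called first, only, known or untested is meant among the compounds shown, and "the series" means these compounds.

Compound 1 `COc1ncnc2c1c(-c1cccs1)cn2[C@@H]1O[C@H](CO)[C@@H](O)[C@H]1O` gives 70 nM; compound 2 `COc1nc(N)nc2c1c(-c1ccco1)cn2[C@@H]1O[C@H](CO)[C@@H](O)[C@H]1O` gives > 20000 nM.

In a functional assay on K562 cells (Homo sapiens), read by MTT assay, with a stated time of 72 h (a higher number here means a weaker inhibitor, a lower number a stronger inhibitor), compound 1 gives 70 nM. Among the compounds with values here, compound 2 reaches only the limit of this assay, > 20000 nM, and it is the one value sitting at the limit of > 20000 nM in this assay, at which 1 of the 2 values shown sits. Compound 3 `COc1ncnc2c1c(-c1ccco1)cn2[C@@H]1O[C@H](CO)[C@@H](O)[C@H]1O` differs from compound 2 by hydrogen in place of amino on an aromatic carbon. Within the data shown here, no measured pair shows this change, so its size is open. Compound 3 is expected to lie well on the stronger side of compound 2's limit, a step of an at least 100-fold lower number from compound 2 to compound 3 (2.00 log units; beyond the scatter) far beyond the scatter. Compound 3 is estimated at 200 nM, between 40 nM and 2000 nM.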

Compound 3, half-maximal inhibitory concentration: 60 nM
The estimate for compound 3 lay 3.3-fold (0.52 log units) above the measured number, and the stated range covers the measured number.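

Compound 2 stands at a limit of this assay, not at a number: the limit of > 20000 nM in this assay, at which 1 of the 3 values shown sits. With furan-2-yl held fixed, hydrogen in place of amino on the aromatic carbon between two ring nitrogen atoms brings an at least 330-fold lower number from compound 2 to compound 3 (2.52 log units; beyond the scatter) and gives the first measured view of this place. With hydrogen on that carbon, furan-2-yl in place of thiophen-2-yl brings a 1.2-fold lower number from compound 1 to compound 3 (0.07 log units; within the scatter) and so leaves these two compounds indistinguishable in this assay.

On these data alone, whether amino has the same effect alongside thiophen-2-yl stays open. So does the outcome with a methylamino group or a chlorine atom on that carbon.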